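The source may hold more compounds than are shown below. What is called first, only, known or untested is meant among the compounds shown, and "the series" means these compounds.

Compound 1 `O=C1NC(=S)S/C1=C\c1cc2cc(Cl)ccc2nc1Cl` was examined in a toxicity assay on HUVEC cells (Homo sapiens) for cytotoxicity, read by MTT assay, with a stated time of 48 h; a higher number here means a weaker inhibitor of growth, a lower number a stronger inhibitor of growth. Compound 1 gives > 100 ug/mL, which is a limit of the assay rather than a number. Compound 2 `Cc1cccc2cc(/C=C3\SC(=S)NC3=O)c(Cl)nc12` gives > 100 ug/mL in this assay, again a limit. Compound 3 `COc1ccc2cc(/C=C3\SC(=S)NC3=O)c(Cl)nc2c1` gives > 100 ug/mL, also a limit. All three measured values thus sit at the limit of > 100 ug/mL in this assay, at which 3 of the 3 values shown sit, so compound 1 stands level with the others and no order among them can be read. Compound 4 `O=C1NC(=S)S/C1=C\c1cc2cc(F)ccc2nc1Cl` differs from compound 1 by fluoro in place of chloro on an aromatic carbon. With nothing in the measured set pointing either way, compound 4 is expected to show no step beyond the scatter, a step that the limit leaves unreadable from compound 1 to compound 4. The estimate for compound 4 is 150 ug/mL, between 60 ug/mL and 400 ug/mL, most likely reported once more only as a limit.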

Compound 4, concentration for 50% growth inhibition: > 100 ug/mL
Compound 4: no number, only a limit; the forecaster's own chance of this, stated with the estimate: 85%; the middle value lies beyond the limit too.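

Compound 1 and compound 4 both stand only at a limit, so no step can be read for fluoro in place of chloro: the limit of > 100 ug/mL in this assay, at which 4 of the 4 values shown sit.

The compounds shown leave open whether any change on the shared core would give a number rather than a limit.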